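Methylsulfonyl and Methylsulfanyl Anilines at the Alpha-1B Receptor

This account rests on a few compounds, and the source may have more. Where it says the series, first, only, none or still open, it means among the compounds named here.

Of the compounds shown here, three have been measured in an assay for binding affinity to Alpha-1B adrenergic receptor (Homo sapiens), read by radioligand binding; a lower number here means a stronger inhibitor, a higher number a weaker inhibitor. Compound 1 `CS(=O)(=O)c1cc(F)ccc1NCC1=NCCN1` gives 513 nM in this assay, compound 2 `CSc1ccc(F)cc1NCC1=NCCN1` gives 40.7 nM, and compound 3 `CSc1ccc(Cl)cc1NCC1=NCCN1` gives 69.2 nM. The difference between the core of compound 1 and the core of compound 2 is not broken down here. Compound 2 to compound 3 is the change (chloro in place of fluoro on an aromatic carbon), and it made a 1.7-fold higher number from compound 2 to compound 3 (0.23 log units; within the scatter). Compound 4 `CS(=O)(=O)c1cc(Cl)ccc1NCC1=NCCN1` carries the same kind of change on the core of compound 1, namely (chloro in place of fluoro on an aromatic carbon); the place differs, being meta to a methylsulfonyl group and para to a group of 7 heavy atoms rather than meta to a group of 7 heavy atoms and para to a methylsulfanyl group. Because the step of a 1.7-fold higher number from compound 2 to compound 3 (0.23 log units; within the scatter) lay within the scatter, a similar small step is expected from compound 1 to compound 4, a 1.5-fold higher number from compound 1 to compound 4 (0.16 log units; within the scatter). Compound 4 is therefore estimated at 750 nM, expected to fall between 300 nM and 1800 nM.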

Compound 4, inhibition constant: 646 nM
Compound 4: middle estimate off by 1.2-fold (0.06 log units), on the high side; the measured number falls inside the stated range.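

Chloro in place of fluoro on an aromatic carbon gave a 1.3-fold higher number from compound 1 to compound 4 (0.10 log units; within the scatter) in this assay, so on this core as well the step is no larger than the scatter. Set beside the earlier step, the change carries over from one core to the other without a difference that can be told apart: the same change on two cores in this assay, a 1.7-fold higher number (0.23 log units; within the scatter) from compound 2 to compound 3 and a 1.3-fold higher number (0.10 log units; within the scatter) from compound 1 to compound 4, 1.4-fold (0.13 log units) apart, within the scatter of two such steps. Among these compounds, this shows only that the step stayed small on these two cores, in this one assay; it does not establish a rule for other cores or for other replacements at this place.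

The compounds shown leave open what bromo, methoxy or an amine would do in place of the halogen. Also open, as far as these compounds go, is what a longer chain on the sulfur would do.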